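This account rests on a few compounds, and the source may have more. Where it says the series, first, only, none or still open, it means among the compounds named here.

In an ADME assay on HepG2 2.2.15 cells (Homo sapiens) for cytotoxicity, read by CCK-8 assay, with a stated time of 8 days (a higher number here means that more compound is tolerated, a lower number that less compound is tolerated), the measured compounds are:

Compound 1 `COc1ccc(-c2cc(NC(=O)c3ccccc3O)c[nH]c2=O)cc1`: > 100000 nM, a limit of the assay and not a number.
Compound 2 `Cc1cccc(-c2cc(NC(=O)c3ccccc3O)c[nH]c2=O)c1`: 98800 nM.
Compound 3 `Cc1cccc(-c2cc(NC(=O)c3ccc(Cl)cc3O)c[nH]c2=O)c1`: 33100 nM.

Of the two true numbers, compound 2 has the higher, and a 3.0-fold lower number from compound 2 to compound 3 (0.47 log units; beyond the scatter) is the gap to the other. Compound 4 `COc1ccc(O)c(C(=O)Nc2c[nH]c(=O)c(-c3cccc(C)c3)c2)c1` carries methoxy in place of hydrogen on an aromatic carbon, para to a hydroxy group (methoxy in place of hydrogen on an aromatic carbon). The closest guide is that modest step, which also replaced hydrogen with a new group. The other step, an at least 1.0-fold lower number from compound 1 to compound 2 (0.00 log units; that floor lies within the scatter), rests on the limit of > 100000 nM in this assay, at which 1 of the 3 values shown sits, and says little. No step beyond the scatter is therefore expected in this assay, though a slightly lower number is possible. The expected step is a 1.4-fold lower number from compound 2 to compound 4 (0.15 log units; within the scatter). For compound 4 the estimate is 70000 nM, with an expected range of 30000 nM to 130000 nM.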

Compound 4, half-maximal cytotoxic concentration: 30100 nM
The estimate for compound 4 lay 2.3-fold (0.37 log units) above the measured number; the range from low to high includes it.
By their numbers in this assay, from the lowest: compounds 4 and 3 (each within the scatter of the next); then compound 2. At a limit, above all of these: compound 1.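

Methoxy para to a hydroxy group is not a neutral change in this assay and gives a 3.3-fold lower number from compound 2 to compound 4 (0.52 log units; beyond the scatter) on the same ring that carries the chloro of the earlier step. Alongside a 3.0-fold lower number from compound 2 to compound 3 (0.47 log units; beyond the scatter) this makes two groups on that ring that each lower the tolerated concentration from the level of compound 2, so the lowering is not tied to chloro alone. No measurement shown explains this lowering.

On these data alone, whether an amine or a carboxylic acid at this same place would also lower the number stays open. So does whether methoxy here would act alike with the 4-methoxyphenyl group of compound 1 in place of 3-methylphenyl.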